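Removing the chloro group from a weak hydroxamic acid series

The compounds below may be only part of what the source reports. "The series", "measured", "known", "first", "only" and "open" are said of these compounds alone.

Measured so far:
compound 1, `O=C(CCC1CCCC1)N(O)c1ccc(Cl)cc1`, 10000 nM
compound 2, `O=C(C1CCCCC1)N(O)c1ccc(Cl)cc1`, 10000 nM
compound 3, `O=C(CC1CCCCC1)N(O)c1ccc(Cl)cc1`, 9000 nM

All three values come from a functional assay on SW-620 cells (Homo sapiens) for inhibition; on this read-out higher numbers stand for weaker inhibition and lower numbers for stronger inhibition. Compound 3 gives the lowest of the three numbers, but its gaps to compound 1 and to compound 2 both lie within the scatter, so the three compounds cannot be told apart on this read-out. For the measured compounds named here, the one step among them that changes a single place, a 1.1-fold lower number from compound 1 to compound 3 (0.05 log units; within the scatter), also stays within the scatter.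

Compound 4, `O=C(CC1CCCCC1)N(O)c1ccccc1`, differs from compound 3 by hydrogen in place of chloro on an aromatic carbon. Going by the values given here, no measured step touches this part of the molecule: the only step recorded concerns the saturated chain on the other side of the carbonyl. With the three measured compounds all sitting at about the same weak level, there is no basis for expecting the change to move the number beyond the scatter in either direction. The expected step is therefore a 1.1-fold higher number from compound 3 to compound 4 (0.05 log units; within the scatter). Compound 4 is estimated to give 10000 nM, with a range from 4000 nM to 30000 nM.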

Compound 4, half-maximal inhibitory concentration: 20000 nM
Compound 4: middle estimate off by 2.0-fold (0.30 log units), on the low side; measured number inside the range.
By their numbers in this assay, from the lowest: compounds 3, 1, 2 and 4 (each within the scatter of the next, the first and the last beyond it).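

Among the compounds shown, this is the first single change that moves the number beyond the scatter: in this assay, hydrogen in place of chloro gives a 2.2-fold higher number from compound 3 to compound 4 (0.35 log units; beyond the scatter), which means weaker inhibition. The step is modest, but it marks the aromatic carbon para to a large group as a place where the substituent counts, whereas the change on the saturated chain, a 1.1-fold lower number from compound 1 to compound 3 (0.05 log units; within the scatter), stayed within the scatter. Nothing available gives a reason for the loss on removing chloro.

On these data alone, it remains open whether chloro itself matters or whether another group on that carbon, such as fluoro, bromo, methyl or methoxy, would serve as well. As far as these compounds go, it is also open whether removing chloro would give a step of similar size in compound 1 or compound 2, with their different saturated groups.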